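The source may report more compounds than this note shows. Statements on the series, on what has been measured and on what is new or still open speak of the compounds shown alone.

Compound 1 `CC1=CC[C@@H]([C@@](C)(O)CCCC(C)(C)NC=S)CC1` carries a thiocarbonyl on the nitrogen without any hydrazone arm. In a functional assay on NCI/ADR cells (Homo sapiens) for cytotoxicity, read by sulforhodamine B assay (on this read-out higher numbers stand for weaker inhibition of growth and lower numbers for stronger inhibition of growth), compound 1 gives only a limit, > 100000 nM. Going by the values given here, compound 2 `CC1=CC[C@@H]([C@@](C)(O)CCCC(C)(C)NC(=S)N/N=C\c2ccc(C)cc2)CC1` extends that thiocarbonyl into a thiosemicarbazone bearing a 4-methylphenyl, and in this assay compound 2 gives 30500 nM, the only real number among the three values shown. Compound 3 `CC1=CC[C@@H]([C@@](C)(O)CCCC(C)(C)NC(=S)N/N=C\c2ccccc2[N+](=O)[O-])CC1` replaces the 4-methylphenyl with 2-nitrophenyl. In this assay compound 3 gives a limit, > 100000 nM. The step shows an at least 3.2-fold higher number from compound 2 to compound 3 (0.51 log units; beyond the scatter), so the nitrophenyl compound sits at the limit where two of the three values stand (the limit of > 100000 nM in this assay, at which 2 of the 3 values shown sit).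

Compound 4 `CC1=CC[C@@H]([C@@](C)(O)CCCC(C)(C)NC(=S)N/N=C\c2cccc([N+](=O)[O-])c2)CC1` is the next variation on compound 2: 3-nitrophenyl in place of 4-methylphenyl on a carbon with a double bond to nitrogen. Among the compounds with values here, the one measured step that bears on this change is the step from compound 2 to compound 3, where a nitrophenyl also replaced the 4-methylphenyl and the number rose at least modestly, beyond the scatter. The same direction is expected here, an estimated step of a 2.3-fold higher number from compound 2 to compound 4 (0.36 log units; beyond the scatter) towards weaker inhibition of growth. For compound 4 in this assay the estimate is 70000 nM, within a range from 30000 nM to 160000 nM, with a fair chance that only a limit is reported.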

Compound 4, concentration for total growth inhibition: 38000 nM
Estimate against measurement, compound 4: 1.8-fold (0.27 log units) above; low and high end bracket the measured number.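

In this assay, the 3-nitrophenyl arm shows that a nitro group on the phenyl does not by itself cost compound 4 a measured number: the change from 4-methylphenyl gives a 1.2-fold higher number from compound 2 to compound 4 (0.10 log units; within the scatter), so compound 2 and compound 4 cannot be told apart here. The two nitrophenyl groups, which count the same atoms, do differ, with an at least 2.6-fold lower number from compound 3 to compound 4 (0.42 log units; beyond the scatter), so among the compounds shown the earlier rise goes with the 2-nitrophenyl and not with a nitrophenyl as such. The value of compound 3 remains a limit and not a number, so the full size of this difference cannot be read: the limit of > 100000 nM in this assay, at which 2 of the 4 values shown sit.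

The compounds shown leave open whether an amine or a carboxylic acid in place of the nitro group on the phenyl would read like the 3-nitrophenyl or like the 2-nitrophenyl in this assay. They also leave open whether a pyridine ring in place of the phenyl would keep a measured number at all.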